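The source may hold more compounds than are shown below. What is called first, only, known or untested is meant among the compounds shown, and "the series" means these compounds.

Measured so far, in a functional assay on MCF7 cells (Homo sapiens) for cytotoxicity, read by MTT assay, with a stated time of 48 h (on this read-out higher numbers stand for weaker inhibition and lower numbers for stronger inhibition), for both compounds:
- compound 1 `Cc1ccc(/C=C2/S/C(=N/c3ccccc3)N(Cc3ccncc3)C2=O)cc1` gives 36900 nM
- compound 2 `COc1ccc(/C=C2/S/C(=N/c3ccccc3)N(Cc3ccncc3)C2=O)cc1OC` gives 80700 nM

Of these two numbers, compound 2 holds the higher one. Still unmeasured is compound 3 `COc1cc(/C=C2/S/C(=N/c3ccccc3)N(Cc3ccncc3)C2=O)ccc1O`, which departs from compound 2 by hydrogen in place of methyl on an oxygen on an aromatic ring. This is hydrogen in place of methyl on an oxygen on an aromatic ring, so 3,4-dimethoxyphenyl becomes 4-hydroxy-3-methoxyphenyl.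

Going by the values given here, no measured pair shows this change directly. Among the compounds with values here, the only step available is a 2.2-fold higher number from compound 1 to compound 2 (0.34 log units; beyond the scatter), a modest one that brought in the 3,4-dimethoxyphenyl group in place of 4-methylphenyl. It exchanges the whole group, so it bears only weakly on the removal of one methyl and fixes no firm direction. In this assay a slight move toward a lower number is expected, though nothing clearly beyond the scatter. The estimated change is a 1.5-fold lower number from compound 2 to compound 3 (0.17 log units; within the scatter) in this read-out. For compound 3 the expected value is 55000 nM with an estimated range from 22000 nM to 120000 nM on repeated measurement.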

Compound 3, half-maximal inhibitory concentration: 28000 nM
The estimate for compound 3 lay 2.0-fold (0.29 log units) above the measured number; measured number inside the range.
By their numbers in this assay, from the lowest: compounds 3 and 1 (each within the scatter of the next); then compound 2.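

In this assay the change from methoxy to hydroxy on the 3,4-dimethoxyphenyl group now has a direct reading, with a 2.9-fold lower number from compound 2 to compound 3 (0.46 log units; beyond the scatter) for the swap of methyl for hydrogen on an oxygen on an aromatic ring, whereas the earlier step exchanged the whole group and could not isolate this one methyl. Against 4-methylphenyl, the resulting 4-hydroxy-3-methoxyphenyl group gives a 1.3-fold lower number from compound 1 to compound 3 (0.12 log units; within the scatter) and so sets no order between those two groups, which leaves compound 2 alone with the highest number of the three and shows that a single methyl on this oxygen is enough to separate it from the other two. No supporting data bear on the reason for this step.

Whether the step depends on the methoxy group that stays on the ring remains open, as compound 3 is the only hydroxy compound shown and a single pair cannot establish a trend. Also open, as far as these compounds go, is how this assay would respond with an ethoxy group, a longer chain on the same oxygen, or with an amine or a carboxylic acid on the aromatic ring in place of the hydroxy group.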